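A few compounds are considered here, and "the series" means these few. Any claim that something is new, unique, unknown or untested is made for them only; others in the source may bear on it.

Three compounds share one core and differ only in the group carried on an amine nitrogen. Compound 1 `COc1cccc(NC2=CC(=O)c3nc4n(c3C2=O)[C@H]2OC[C@@H](O)[C@H]2OC4)c1` gives 4280 nM in a functional assay on HeLa cells (Homo sapiens) for inhibition, read by sulforhodamine B assay; on this read-out higher numbers stand for weaker inhibition and lower numbers for stronger inhibition. Compound 2 `CCc1ccc(NC2=CC(=O)c3nc4n(c3C2=O)[C@H]2OC[C@@H](O)[C@H]2OC4)cc1` gives 3990 nM in this assay, and compound 3 `CCOc1ccc(NC2=CC(=O)c3nc4n(c3C2=O)[C@H]2OC[C@@H](O)[C@H]2OC4)cc1` gives 3110 nM in this assay. Compound 3 has the lowest of the three numbers, yet the steps of a 1.4-fold lower number from compound 1 to compound 3 (0.14 log units; within the scatter) and a 1.3-fold lower number from compound 2 to compound 3 (0.11 log units; within the scatter) are both small, as is a 1.1-fold lower number from compound 1 to compound 2 (0.03 log units; within the scatter).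

Compound 4 `O=C1C=C(Nc2cccc(F)c2)C(=O)c2c1nc1n2[C@H]2OC[C@@H](O)[C@H]2OC1` has not yet been measured. Its change from compound 3 is this: 3-fluorophenyl in place of 4-ethoxyphenyl on an amine nitrogen. All three measured steps swap one group on this same amine nitrogen, and none of them moved the number beyond the scatter, which suggests the nitrogen-bound ring tolerates such exchanges. From the compounds shown here alone, none of them, however, brings in a fluorine, so the new group itself is untested. The expected step is therefore a 1.3-fold higher number from compound 3 to compound 4 (0.11 log units; within the scatter), meaning no change beyond the scatter. Compound 4 is thus expected to give 4000 nM in this assay. The estimate for compound 4 is expected to lie between 1500 nM and 11000 nM.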

Compound 4, half-maximal inhibitory concentration: 6440 nM
Estimate against measurement, compound 4: 1.6-fold (0.21 log units) below; the range from low to high includes it.
By their numbers in this assay, from the lowest: compounds 3, 2, 1 and 4 (each within the scatter of the next, the first and the last beyond it).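

Among these compounds, the 3-fluorophenyl group gives the first exchange on this amine nitrogen that passes the usual scatter (a 2.1-fold higher number from compound 3 to compound 4 (0.32 log units; beyond the scatter)), so the group carried here is not wholly without effect, although the step is modest. That gap appears only against compound 3, since the other two new steps stay within the scatter (a 1.6-fold higher number from compound 2 to compound 4 (0.21 log units; within the scatter); a 1.5-fold higher number from compound 1 to compound 4 (0.18 log units; within the scatter)), and the second of these is a plain swap of fluoro for methoxy on an aromatic carbon. Nothing available explains why the exchange from compound 3 gave the larger step.

The step from compound 3 changes both the substituent and its location on the ring, so a 4-fluorophenyl group would be needed to separate the two. From the compounds shown here alone, it also remains open how a ring bearing an amine, a carboxylic acid or a longer alkoxy chain would behave at this nitrogen.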